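Methylating the Amide Nitrogen of a Diphenyl Carbamoyl Antagonist

A few compounds are considered here, and "the series" means these few. Any claim that something is new, unique, unknown or untested is made for them only; others in the source may bear on it.

Within the data shown here, compound 2 `CNC(=O)C(CCn1ccnc1C)(c1ccccc1)c1ccccc1` holds the higher of the two numbers measured so far in an assay on ileum with muscarinic acetylcholine receptor M3 (Cavia porcellus) as the target (a higher number here means a weaker inhibitor, a lower number a stronger inhibitor), where compound 2 gives 5150 nM. Among the measured compounds shown here, its neighbour compound 1 `Cc1nccn1CCC(CO)(c1ccccc1)c1ccccc1` gives 25.4 nM, and the single measured step, a 200-fold higher number from compound 1 to compound 2 (2.31 log units; beyond the scatter), concerns the carbamoyl group rather than its nitrogen. Compound 3 `Cc1nccn1CCC(C(=O)N(C)C)(c1ccccc1)c1ccccc1` differs from compound 2 by methyl in place of hydrogen on an amide-type nitrogen. For the measured compounds named here, no measured step bears on this change, so for compound 3 the expected step is a 1.0-fold lower number from compound 2 to compound 3 (0.01 log units; within the scatter), a number not beyond the scatter. Compound 3 is therefore estimated at 5000 nM, with a range of 1500 nM to 15000 nM.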

Compound 3, antagonist equilibrium constant: 258 nM
Compound 3: the middle estimate sits 19-fold (1.29 log units) above what was measured, and the stated range ends above it.
By their numbers in this assay, from the lowest: compound 1; then compound 3; then compound 2.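

The amide nitrogen matters: methyl in place of the amide hydrogen, the change from methylcarbamoyl to dimethylcarbamoyl, wins back part of what the carbamoyl group lost (a 20-fold lower number from compound 2 to compound 3 (1.30 log units; beyond the scatter)). The hydroxymethyl group still keeps the lowest number of the three (a 10-fold higher number from compound 1 to compound 3 (1.01 log units; beyond the scatter)). No measurement shown here explains the effect of this extra methyl. Still open, on these data alone, is how a longer chain on this nitrogen, such as ethyl, would read. Also open, as far as these compounds go, is whether an amine or a carboxylic acid in place of the carbamoyl group would read closer to hydroxymethyl.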